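A few compounds are considered here, and "the series" means these few. Any claim that something is new, unique, unknown or untested is made for them only; others in the source may bear on it.

Compound 1 `CCN(CC)c1nc(C)c2[nH]c(SCC(=O)NCCNC(=N)N)nc2n1` in an ADME assay on CEM174 cells (Homo sapiens) for cytotoxicity (a higher number here means that more compound is tolerated, a lower number that less compound is tolerated), gives > 100 uM, which is a limit of the assay and not a number.
Compound 2 `CCN(CC)c1nc(C)c2[nH]c(SCC(=O)NCCCNC(=N)N)nc2n1` in this assay gives > 100 uM, again a limit.
Compound 3 `CCN(CC)c1nc(C)c2[nH]c(SCC(=O)NCCNC(=N)N)[n+](CCCN(C)C)c2n1` in this assay gives > 100 uM, also a limit.

From compound 1 to compound 2 the change is a group of 5 heavy atoms (2 carbon, 3 nitrogen; no ring) in place of a group of 4 heavy atoms (1 carbon, 3 nitrogen; no ring), on a saturated chain carbon, two bonds along the chain from an amide-type nitrogen. The matching step in this assay is a step that the two limits leave unreadable from compound 1 to compound 2. Compound 3 and compound 1 differ in more than one place, and the difference between the two cores is not broken down here. Compound 4 `CCN(CC)c1nc(C)c2[nH]c(SCC(=O)NCCCNC(=N)N)[n+](CCCN(C)C)c2n1` carries the same change relative to compound 3, namely (a group of 5 heavy atoms (2 carbon, 3 nitrogen; no ring) in place of a group of 4 heavy atoms (1 carbon, 3 nitrogen; no ring), on a saturated chain carbon, two bonds along the chain from an amide-type nitrogen), at the same place. The step in this assay from compound 3 to compound 4 is expected to be a number no higher from compound 3 to compound 4 (the limit leaves the size open), an expectation that rests on (the limit of > 100 uM in this assay, at which 3 of the 3 values shown sit). For compound 4 in this assay the estimate is 100 uM, most likely reported once more as a limit.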

Compound 4, half-maximal toxic concentration: > 100 uM
Compound 4 ended at the assay's limit; the forecaster's own chance of this, stated with the estimate: 90%; the middle value sits exactly at the limit.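

Among these compounds, compound 3 and compound 4 each give only a limit in this assay, so no step between them can be read. The compounds shown leave open whether the group of 5 heavy atoms, in place of the group of 4 heavy atoms, changes how much compound is tolerated.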